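Tertiary amine on a propyl chain replaces the diamine

A few compounds are considered here, and "the series" means these few. Any claim that something is new, unique, unknown or untested is made for them only; others in the source may bear on it.

Compound 3 `CCCCCCCCCCc1ccc(-c2noc([C@H](N)CCCCN)n2)cc1` stands second highest of the three numbers in an assay on HeLa cells for inhibition of sphingosine-1-phosphate transporter SPNS2 (Mus musculus), read by LC-MS, tested at 2 uM (on this read-out lower numbers stand for less inhibition and higher numbers for more inhibition at the one concentration tested (going by the name of the read-out)), where compound 3 gives 50%. Its nearest neighbour is compound 1 `CCCCCCCCCCc1ccc(-c2noc(C3CNC3)n2)cc1`, for which compound 1 gives 65%; the furthest is compound 2 `CCCCCCCCCCc1ccc(-c2noc(CCCN(C)C)n2)cc1`, for which compound 2 gives 8%. The two steps that touch compound 3 are a number 15 percentage points lower from compound 1 to compound 3 (beyond the scatter) and a number 42 percentage points higher from compound 2 to compound 3 (beyond the scatter).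

Compound 4 `CCCCCCCCCCc1ccc(-c2noc(CCCN3CCCC3)n2)cc1` differs from compound 3 in one place: 3-(pyrrolidin-1-yl)propyl in place of 1,5-diaminopentyl on an aromatic carbon. The measured step that bears most directly on this change is a number 42 percentage points higher from compound 2 to compound 3 (beyond the scatter), since the 3-(dimethylamino)propyl group of compound 2 and the 3-(pyrrolidin-1-yl)propyl group of compound 4 are both propyl chains ending in an amine with no hydrogen-bond donor, while 1,5-diaminopentyl carries two. The step of a number 57 percentage points lower from compound 1 to compound 2 (beyond the scatter) points the same way: moving from azetidin-3-yl to 3-(dimethylamino)propyl was a large loss. Compound 4 is therefore expected to sit near compound 2, and the expected step is a number 35 percentage points lower from compound 3 to compound 4 (beyond the scatter), a large fall in this assay beyond the scatter. Whether pyrrolidin-1-yl behaves exactly as dimethylamino is not known from the three compounds, so the range is kept wide.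

For compound 4 the estimate in this assay is 15%, expected between 0% and 40%.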

Compound 4, a percentage reported as inhibition, at one concentration (the size of the read-out at that concentration, not a potency): 3%
For compound 4 the middle estimate is 12 percentage points above the measured one; low and high end bracket the measured number.
By their numbers in this assay, from the lowest: compounds 4 and 2 (each within the scatter of the next); then compound 3; then compound 1.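

In this assay, the step of a number 5 percentage points lower from compound 2 to compound 4 (within the scatter) shows that pyrrolidin-1-yl and dimethylamino cannot be told apart at the end of the propyl chain, so closing the terminal amine into a five-membered ring does not recover the read-out. The steps of a number 47 percentage points lower from compound 3 to compound 4 (beyond the scatter) and a number 62 percentage points lower from compound 1 to compound 4 (beyond the scatter) place this second propyl amine far from both 1,5-diaminopentyl and azetidin-3-yl on this aromatic carbon, which makes the low read-out of compound 2 more than a feature of dimethylamino alone. The change from compound 3 to compound 4 alters the hydrogen-bond donor count, chain, ring and stereocentre together, and no measurement here says which of these accounts for the fall.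

On these data alone, whether a primary amine or a secondary methylamine at the end of the propyl chain would give a read-out nearer to that of compound 3 stays open. So does the effect of a pyrrolidin-3-yl or piperidin-4-yl group on the same aromatic carbon, which would show whether the read-out of compound 1 extends to other ring amines without the propyl chain.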